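This account rests on a few compounds, and the source may have more. Where it says the series, first, only, none or still open, it means among the compounds named here.

Measured compounds:
compound 1, `COC(=O)CCCNC(=O)CN1CN(c2ccccc2)C2(CCN(C(=O)c3ccc(C4CCCCC4)cc3)CC2)C1=O` — 2500 nM in an assay on HEK293 cells for displacement of a labelled ligand from NPC1-like intracellular cholesterol transporter 1 (Homo sapiens); a higher number here means a weaker inhibitor, a lower number a stronger inhibitor
compound 2, `COC(=O)CCCNC(=O)CN1CN(c2ccccc2)C2(CCN(C(=O)c3ccc(C(C)(C)C)cc3)CC2)C1=O` — "not determined" (no result reported) in this assay

Compound 1 holds the only number shown; compound 2 gives no result, so compound 1 cannot be ranked against anything. The unmeasured compound 3, `CS(=O)(=O)N1CCN(C(=O)CN2CN(c3ccccc3)C3(CCN(C(=O)c4ccc(C5CCCCC5)cc4)CC3)C2=O)CC1`, differs from compound 1 by 4-(methylsulfonyl)piperazin-1-yl in place of (3-(methoxycarbonyl)propyl)amino on a carbonyl carbon. Without any measured step for comparison, the size of this change can only be guessed; a shift either way is plausible, but nothing beyond the scatter is expected with confidence. For compound 3 in this assay, the estimate is 2000 nM (range 600 nM to 7000 nM), meaning an expected step of a 1.3-fold lower number from compound 1 to compound 3 (0.10 log units; within the scatter).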

Compound 3, half-maximal inhibitory concentration: 6300 nM
Compound 3: middle estimate off by 3.2-fold (0.50 log units), on the low side, within the range that was stated.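

Placing 4-(methylsulfonyl)piperazin-1-yl instead of (3-(methoxycarbonyl)propyl)amino on this carbonyl carbon gives a 2.5-fold higher number from compound 1 to compound 3 (0.40 log units; beyond the scatter) in this assay and is the first sign that this position responds to its substituent. The change is modest, and it gives up the open chain and its hydrogen-bond donor at once, so this single step cannot separate the two. Nothing measured here accounts for the loss.

Still open, going by these compounds, is what this assay would give for a carboxylic acid in place of the methoxycarbonyl group, or for a longer chain. A piperazine without the methylsulfonyl group would show whether the ring or the sulfonyl part carries the step.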